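Replacing the piperidin-4-yl group of compound 3

The source may report more compounds than this note shows. Statements on the series, on what has been measured and on what is new or still open speak of the compounds shown alone.

Compound 1 `O=S(=O)(c1ccc([C@H]2CC[C@]3(CC2)OOC2(O3)C3CC4CC(C3)CC2C4)cc1)N1CCNCC1`, compound 2 `N[C@H]1CC[C@H](Oc2ccc([C@H]3CC[C@]4(CC3)OOC3(O4)C4CC5CC(C4)CC3C5)cc2)CC1` and compound 3 `c1cc([C@H]2CC[C@]3(CC2)OOC2(O3)C3CC4CC(C3)CC2C4)ccc1OC1CCNCC1` share a core and have been measured in an ADME assay on microsomes from liver (Homo sapiens) for metabolic stability, read by LC-MS, tested at 1 uM; a lower number here means slower removal, a higher number faster removal of the compound. There compound 1 gives 16 mL.min-1.g-1 and compound 3 gives 15 mL.min-1.g-1, so compound 3 stands level with compound 1 within the scatter. Compound 2 gives < 7 mL.min-1.g-1, which is a limit of the assay and not a number.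

The next compound is compound 4 `CC(C)(CN)Oc1ccc([C@H]2CC[C@]3(CC2)OOC2(O3)C3CC4CC(C3)CC2C4)cc1`. The change is 1-(aminomethyl)-1-methylethyl in place of piperidin-4-yl on an oxygen on an aromatic ring, with 1-(aminomethyl)-1-methylethyl in place of piperidin-4-yl on an oxygen on an aromatic ring. The measured step closest to it alters the same group on the same oxygen: an at least 2.1-fold higher number from compound 2 to compound 3 (0.33 log units; beyond the scatter), with piperidin-4-yl in place of 4-aminocyclohexyl. The wider exchange in a 1.1-fold lower number from compound 1 to compound 3 (0.03 log units; within the scatter) bears on it less directly. Compound 4, like compound 2, has no piperidin-4-yl group on that oxygen, so the expectation leans towards compound 2, whose step to compound 3 was an at least 2.1-fold higher number from compound 2 to compound 3 (0.33 log units; beyond the scatter). The new chain is not the group of compound 2, however, so only part of that step is expected to carry over in this assay. The expected change is small and downward, a 1.5-fold lower number from compound 3 to compound 4 (0.18 log units; within the scatter). For compound 4 the estimate is 10 mL.min-1.g-1, with an expected range from 5 mL.min-1.g-1 to 22 mL.min-1.g-1.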

Compound 4, intrinsic clearance in microsomes: < 7 mL.min-1.g-1
Compound 4: no number, only a limit; the forecaster's own chance of this, stated with the estimate: 30%; at least 1.4-fold (0.15 log units) between middle value and limit.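

Going by these compounds alone, the new compound shows that the piperidin-4-yl group is not the only kind of basic-looking group this oxygen will carry at a high number, and it also shows that an open chain can take the place of that ring with a clear shift in this assay: an at least 2.1-fold lower number from compound 3 to compound 4 (0.33 log units; beyond the scatter). Compound 2 keeps a ring on the same oxygen and compound 4 has none, yet both sit at the limit, so the presence of a ring alone does not separate piperidin-4-yl from the other two groups. The exchange against the sulfonyl compound also now gives a step beyond the scatter, an at least 2.2-fold lower number from compound 1 to compound 4 (0.35 log units; beyond the scatter), whereas a 1.1-fold lower number from compound 1 to compound 3 (0.03 log units; within the scatter).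

The step between compound 2 and compound 4 cannot be read, because both stand at the same limit and neither gives a number: the limit of < 7 mL.min-1.g-1 in this assay, at which 2 of the 4 values shown sit. How a piperidin-4-yl ring with a methyl group on its nitrogen, or an open chain ending in a secondary amine, would read in this assay is left open by the compounds shown.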